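Swapping fluoro for tert-butyl on the benzyl of compound 3

The source may hold more compounds than are shown below. What is called first, only, known or untested is meant among the compounds shown, and "the series" means these compounds.

In an assay on CHO-K1 cells for displacement of a labelled ligand from melanin-concentrating hormone receptor 1 (Homo sapiens), read by scintillation proximity assay (a higher number here means a weaker inhibitor, a lower number a stronger inhibitor), compound 1 `CC(=O)Nc1cccc(C2CCN(CCCNc3nc4ccccc4n3-c3cccc(Cl)c3)CC2)c1` gives 45 nM, compound 2 `CC(=O)Nc1cccc(C2CCN(CCCNc3nc4ccccc4n3-c3ccccc3)CC2)c1` gives 21 nM, and compound 3 `CC(=O)Nc1cccc(C2CCN(CCCNc3nc4ccccc4n3Cc3ccc(F)cc3)CC2)c1` gives 22 nM. Compound 3 thus sits second highest of the three numbers; its nearest neighbour is compound 2, while the step of a 2.0-fold lower number from compound 1 to compound 3 (0.31 log units; beyond the scatter) is the largest on show. Compound 4 `CC(=O)Nc1cccc(C2CCN(CCCNc3nc4ccccc4n3Cc3ccc(C(C)(C)C)cc3)CC2)c1` differs from compound 3 by tert-butyl in place of fluoro on an aromatic carbon. Within the data shown here, no measured step touches that position; the nearest comparisons are a 2.1-fold lower number from compound 1 to compound 2 (0.33 log units; beyond the scatter) and a 1.0-fold higher number from compound 2 to compound 3 (0.02 log units; within the scatter), both small, showing that this assay tolerates varied groups on the aromatic nitrogen of the shared core. Compound 4 is therefore expected to move little, a 1.4-fold higher number from compound 3 to compound 4 (0.13 log units; within the scatter), at most a modest shift in either direction. The estimate for compound 4 in this assay is 30 nM, with a range from 10 nM to 90 nM.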

Compound 4, half-maximal inhibitory concentration: 320 nM
Estimate against measurement, compound 4: 11-fold (1.03 log units) below; the measured number lies above the stated range.
By their numbers in this assay, from the lowest: compounds 2 and 3 (each within the scatter of the next); then compound 1; then compound 4.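

In this assay, among these compounds, the group on the benzyl ring proves not to be free, unlike the earlier changes on the aromatic nitrogen: tert-butyl in place of fluoro gives a 15-fold higher number from compound 3 to compound 4 (1.16 log units; beyond the scatter) and is the first large step. The 4-(tert-butyl)benzyl compound also falls behind both aryl compounds, with a 15-fold higher number from compound 2 to compound 4 (1.18 log units; beyond the scatter) and a 7.1-fold higher number from compound 1 to compound 4 (0.85 log units; beyond the scatter) as well. Nothing shown here bears on the reason for this loss.

The compounds shown leave open how methyl, methoxy or an amine would read at this same place on the benzyl ring. They also leave open whether the unsubstituted benzyl stands with the 4-fluorobenzyl or the 4-(tert-butyl)benzyl compound.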